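Hydrazone aryl variation on the shared core

The source may report more compounds than this note shows. Statements on the series, on what has been measured and on what is new or still open speak of the compounds shown alone.

Compound 1 `Cn1c(=O)c(=O)n(C2CCCC2)c2nc(N/N=C/c3ccccc3)ncc21` gives > 100000 nM in a functional assay on A549 cells (Homo sapiens) for antiproliferative activity, read by MTT assay (on this read-out higher numbers stand for weaker inhibition and lower numbers for stronger inhibition), which is a limit of the assay and not a number. Compound 2 `Cn1c(=O)c(=O)n(C2CCCC2)c2nc(N/N=C/c3ccc(S(C)(=O)=O)cc3)ncc21` gives 84500 nM in this assay, and compound 3 `Cn1c(=O)c(=O)n(C2CCCC2)c2nc(N/N=C/c3ccc(O)c(Br)c3)ncc21` gives 12800 nM. The step of an at least 1.1-fold lower number from compound 1 to compound 2 (0.07 log units; that floor lies within the scatter) stays within the scatter and is bounded by the limit of > 100000 nM in this assay, at which 1 of the 3 values shown sits, whereas the steps of an at least 7.8-fold lower number from compound 1 to compound 3 (0.89 log units; beyond the scatter) and a 6.6-fold lower number from compound 2 to compound 3 (0.82 log units; beyond the scatter) reach beyond it. Compound 4 `Cn1c(=O)c(=O)n(C2CCCC2)c2nc(N/N=C/c3ccc(F)cc3F)ncc21` carries 2,4-difluorophenyl in place of phenyl on a carbon with a double bond to nitrogen. For the measured compounds named here, no measured step places fluorine on that ring, so the closest guide is the small step to compound 2. The expected step of an at least 1.4-fold lower number from compound 1 to compound 4 (0.15 log units; that floor lies within the scatter) is therefore small or none beyond the scatter. Compound 4 is estimated at 70000 nM, with a range from 20000 nM to 200000 nM.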

Compound 4, half-maximal inhibitory concentration: 18300 nM
Compound 4: the middle estimate sits 3.8-fold (0.58 log units) above what was measured, outside the stated range (below it).
By their numbers in this assay, from the lowest: compounds 3 and 4 (each within the scatter of the next); then compound 2. At a limit, above all of these: compound 1.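

On the carbon with a double bond to nitrogen, 2,4-difluorophenyl in place of phenyl gives an at least 5.4-fold lower number from compound 1 to compound 4 (0.73 log units; beyond the scatter) in this assay, so this change reaches beyond the scatter without the hydroxyl or bromine of compound 3. The aryl groups of compound 3 and compound 4 are not separated, with a 1.4-fold higher number from compound 3 to compound 4 (0.16 log units; within the scatter), while a 4.6-fold lower number from compound 2 to compound 4 (0.66 log units; beyond the scatter) sets 2,4-difluorophenyl apart from 4-(methylsulfonyl)phenyl. Compound 1 stands at a limit, so the first step is only a floor: the limit of > 100000 nM in this assay, at which 1 of the 4 values shown sits.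

Going by these compounds, whether one fluorine would suffice remains open. So does how an amine or a carboxylic acid on this aromatic ring would read out.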